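The source may hold more compounds than are shown below. What is called first, only, known or untested is meant among the compounds shown, and "the series" means these compounds.

Measured so far in an ADME assay on RAW264.7 cells (Mus musculus) for cytotoxicity, read by MTT assay, with a stated time of 48 h; on this read-out higher numbers stand for weaker inhibition and lower numbers for stronger inhibition:

Compound 1 `Cc1cc(NC(=O)c2cc(C(F)(F)F)cc(C(F)(F)F)c2)ccc1NS(=O)(=O)C(F)(F)F` gives 40700 nM in this assay.

Compound 2 `CCS(=O)(=O)Nc1ccc(NC(=O)c2cc(C(F)(F)F)cc(C(F)(F)F)c2)cc1OC` gives no number in this assay but only a limit of the assay, > 250000 nM.

Going by the values given here, compound 2 therefore stands at the limit of > 250000 nM in this assay, at which 1 of the 2 values shown sits, so its place on the scale is known only as a bound, and no measured step leads from it to any other compound here. Compound 3 `COc1cc(NC(=O)c2cc(C(F)(F)F)cc(C(F)(F)F)c2)ccc1NS(=O)(=O)C(F)(F)F` is the compound not yet measured. It differs from compound 2 in one place: trifluoromethyl in place of ethyl on a sulfonyl sulfur. No measured pair shows this exchange, so the size of the step rests on the two compounds shown alone. Compound 1, which bears the ((trifluoromethyl)sulfonyl)amino group, gives a number in this assay, whereas compound 2 does not. For compound 3 a step toward stronger inhibition, beyond the scatter, is expected, an at least 3.5-fold lower number from compound 2 to compound 3 (0.55 log units; beyond the scatter). Compound 3 is thus estimated at 70000 nM, within a range from 20000 nM to 250000 nM, with a real chance that the assay again reports only a limit.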

Compound 3, half-maximal inhibitory concentration: > 250000 nM
Compound 3: only a limit was reported (the forecaster's own chance of this, stated with the estimate: 35%); at least 3.5-fold (0.55 log units) between middle value and limit.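

Held against compound 1 in this assay the change of methoxy in place of methyl on an aromatic carbon gives an at least 6.1-fold higher number from compound 1 to compound 3 (0.78 log units; beyond the scatter), with the ((trifluoromethyl)sulfonyl)amino group the same in both. That group therefore does not bring a measured number on its own, and the aromatic carbon turns out to be a place where a single exchange moves the read-out beyond the scatter. Trifluoromethyl in place of ethyl on a sulfonyl sulfur cannot be read, as compound 2 and compound 3 each carry only a limit of the assay and share the same one: the limit of > 250000 nM in this assay, at which 2 of the 3 values shown sit.

Going by these compounds, how far compound 2 and compound 3 lie past that limit, and whether they differ from each other at all, remains open. Also open, on these data alone, is whether a chlorine or an ethoxy group on that aromatic carbon, or a propyl chain on the sulfonyl sulfur, would bring the read-out back to a number.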